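Sulfonamide series: trimming the biphenyl of compound 2

The source may report more compounds than this note shows. Statements on the series, on what has been measured and on what is new or still open speak of the compounds shown alone.

Measured compounds:
- compound 1 `COc1cccc(CNCCCNS(=O)(=O)c2cc(C(F)(F)F)cc(C(F)(F)F)c2)c1` — 10000 nM
- compound 2 `O=S(=O)(NCCCNCc1ccc(-c2ccccc2)cc1)c1cc(C(F)(F)F)cc(C(F)(F)F)c1` — 2300 nM

In a functional assay on HT-29 cells (Homo sapiens) for inhibition, read by MTT assay, with a stated time of 72 h (on this read-out lower numbers stand for stronger inhibition of growth and higher numbers for weaker inhibition of growth), compound 2 gives 2300 nM. In this assay compound 1 gives 10000 nM. Among the measured compounds shown here, compound 2 therefore stands at the lowest of the two numbers measured so far, and its separation from compound 1 lies beyond the scatter of repeated measurements. Both share the same bis(trifluoromethyl)phenylsulfonamide core and three-carbon chain; they differ only in the benzylic aryl group.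

Compound 3 `O=S(=O)(NCCCNCc1ccccc1)c1cc(C(F)(F)F)cc(C(F)(F)F)c1` is not yet measured. It differs from compound 2 as follows: hydrogen in place of phenyl on an aromatic carbon. For the measured compounds named here, no step between two measured compounds tracks this exact change, so the size of the step has to be judged from compound 1 and compound 2 alone. Compound 1, which carries a smaller methoxy-substituted benzyl in place of the biphenylmethyl, gives 10000 nM, a weaker result than compound 2; a plain benzyl is expected to fall in a similar region, so the step from compound 2 to compound 3 is expected to be upward and beyond the scatter, about a 3.5-fold higher number from compound 2 to compound 3 (0.54 log units; beyond the scatter). Compound 3 is estimated at 8000 nM, within a range of 3000 nM to 20000 nM.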

Compound 3, concentration for 50% growth inhibition: 15000 nM
The estimate for compound 3 lay 1.9-fold (0.27 log units) below the measured number; low and high end bracket the measured number.
By their numbers in this assay, from the lowest: compound 2; then compounds 1 and 3 (each within the scatter of the next).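

In this assay, hydrogen in place of phenyl on an aromatic carbon, para to a large group, gives a 6.5-fold higher number from compound 2 to compound 3 (0.81 log units; beyond the scatter), so a single-place comparison now ties the phenyl of compound 2 to its lower number. Hydrogen in place of methoxy gives a 1.5-fold higher number from compound 1 to compound 3 (0.18 log units; within the scatter), so the methoxy of compound 1 does not separate that compound from the unsubstituted benzyl of compound 3; of the two aryl substituents compared with hydrogen, only the phenyl produces a step beyond the scatter. No available data bear on the reason for the phenyl step, and the result remains a description of these growth-inhibition numbers alone.

The compounds shown leave open whether that aromatic carbon needs a whole phenyl ring or whether a smaller or non-aromatic group, such as chlorine, methyl or cyclohexyl, would give a similar number. They also leave open whether the phenyl step would hold with a longer chain in place of the present linker, or with an amide in place of the amine.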